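Moving the Methoxy Group on a Urea Ligand

The compounds below may be only part of what the source reports. "The series", "measured", "known", "first", "only" and "open" are said of these compounds alone.

Compound 1 `COc1ccc(NC(=O)NC(CCN(C)C)c2ccc(Cl)cc2)cc1` is a urea that carries a 4-methoxyphenyl group on one amide-type nitrogen. Among the compounds with values here, in an assay on NIH3T3 cells with Urotensin-2 receptor (Homo sapiens) as the target (on this read-out lower numbers stand for an effect already at smaller amounts and higher numbers for an effect only at larger amounts of compound), compound 1 gives 2000 nM, the highest of the two numbers measured so far. Compound 2 `CN(C)CCC(NC(=O)Nc1ccc(C(F)(F)F)cc1)c1ccc(Cl)cc1` gives 117 nM in this assay, and the step of a 17-fold lower number from compound 1 to compound 2 (1.23 log units; beyond the scatter) shows that exchanging the group on that ring changes the read-out strongly. Compound 3 `COc1cccc(NC(=O)NC(CCN(C)C)c2ccc(Cl)cc2)c1` differs from compound 1 in another way: 3-methoxyphenyl in place of 4-methoxyphenyl on an amide-type nitrogen. Within the data shown here, no measured step tells what happens when the methoxy group is moved rather than replaced; the only step known, that from compound 1 to compound 2, replaces the group itself and so bears only loosely on this change. Compound 3 is therefore expected to sit close to compound 1, with no change at the digits printed from compound 1 to compound 3 (within the scatter) expected to stay within the scatter. The estimate for compound 3 in this assay is 2000 nM, with a range from 600 nM to 7000 nM.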

Compound 3, half-maximal effective concentration: 1350 nM
Compound 3: middle estimate off by 1.5-fold (0.17 log units), on the high side, within the range that was stated.
By their numbers in this assay, from the lowest: compound 2; then compounds 3 and 1 (each within the scatter of the next).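

In this assay, a 1.5-fold lower number from compound 1 to compound 3 (0.17 log units; within the scatter), so 3-methoxyphenyl and 4-methoxyphenyl on this amide-type nitrogen cannot be told apart on this read-out. The earlier step, a 17-fold lower number from compound 1 to compound 2 (1.23 log units; beyond the scatter), changed the group itself; taken together, the two steps show a large shift when trifluoromethyl replaces methoxy, but none that can be read when the methoxy group is only moved. Nothing available explains why the read-out holds when the group moves.

Still open, on these data alone, is whether a different group on this ring, such as a nitrile or an ethoxy group, would give a number nearer that of compound 1 or that of compound 2. It is also unknown whether a trifluoromethyl group would tolerate the same move as the methoxy group.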